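Anilino enone series: indolyl in place of fluorophenyl

The source may report more compounds than this note shows. Statements on the series, on what has been measured and on what is new or still open speak of the compounds shown alone.

Compound 1 `O=C(/C=C\Nc1ccc(F)cc1)c1nc(-c2ccc(C(F)(F)F)cc2)n2ccccc12` is the starting point. In a functional assay on MDA-MB-231 cells (Homo sapiens) for cytotoxicity, read by MTT assay, with a stated time of 48 h (on this read-out lower numbers stand for stronger inhibition and higher numbers for weaker inhibition), compound 1 gives > 30000 nM, which is a limit of the assay rather than a number. Compound 2 `COc1ccc(N/C=C\C(=O)c2nc(-c3ccc(F)cc3)n3ccccc23)cc1OC` gives > 30000 nM in this assay, again a limit. Compound 3 `COc1ccc(-c2nc(C(=O)/C=C\Nc3ccc(F)cc3)c3ccccn23)cc1` gives > 30000 nM in this assay, also a limit. For the measured compounds named here, the only single-point step among the measured compounds, a step that the two limits leave unreadable from compound 1 to compound 3, cannot be sized because the limit of > 30000 nM in this assay, at which 3 of the 3 values shown sit, holds both of its ends. Compound 4 `O=C(/C=C\Nc1ccc2cc[nH]c2c1)c1nc(-c2ccc(C(F)(F)F)cc2)n2ccccc12` differs from compound 1 by 1H-indol-6-yl in place of 4-fluorophenyl on an amine nitrogen. Going by the values given here, no measured step touches the amine substituent, since compound 2 also carries 4-fluorophenyl on the amine nitrogen, so the measured compounds say nothing about how far the (1H-indol-6-yl)amino variant moves. With every measured value sitting at the limit, the expected step of a number no higher from compound 1 to compound 4 (the limit leaves the size open) for compound 4 is of unreadable size. The working expectation is that compound 4 returns another limit in this assay. The estimate for compound 4 is 30000 nM, with a range from 5000 nM to 100000 nM.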

Compound 4, half-maximal inhibitory concentration: > 30000 nM
Compound 4: only a limit was reported; the forecaster's own chance of this, stated with the estimate: 70%; the middle value sits exactly at the limit.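

No step can be read from compound 1 to compound 4, since both ends rest on the same limit: the limit of > 30000 nM in this assay, at which 4 of the 4 values shown sit. The compounds shown leave open whether any change on the shared core, 1H-indol-6-yl on the amine nitrogen included, moves the read-out in this assay.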